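Chloro for methyl on the aromatic ring of compound 1

The source may report more compounds than this note shows. Statements on the series, on what has been measured and on what is new or still open speak of the compounds shown alone.

For the measured compounds named here, compound 1 `CCOC(=O)Nc1ccc(S(=O)(=O)N2C[C@H](c3ccccc3)NC2=O)cc1C` gives 70 nM in a functional assay on HCT-116 cells (Homo sapiens) for cytotoxicity, read by MTT assay (a lower number here means a stronger inhibitor, a higher number a weaker inhibitor), the only number among the three measured compounds. Compound 2 `Cc1cc(S(=O)(=O)N2C(=O)N[C@@H](c3ccccc3)C2C)ccc1NC(=O)c1ccc([N+](=O)[O-])cc1` reaches only the limit > 10000 nM. Compound 3 `CCOC(=O)Nc1c(C)cc(S(=O)(=O)N2C[C@H](c3ccccc3)NC2=O)cc1C` likewise stops at the limit > 10000 nM, which is the limit of > 10000 nM in this assay, at which 2 of the 3 values shown sit. Going by the values given here, the single step between compounds differing in one place, an at least 140-fold higher number from compound 1 to compound 3 (2.15 log units; beyond the scatter), is large. Compound 4 `CCOC(=O)Nc1ccc(S(=O)(=O)N2C[C@H](c3ccccc3)NC2=O)cc1Cl` differs from compound 1 by chloro in place of methyl on an aromatic carbon. Among the compounds with values here, no measured step swaps one group for another at an aromatic carbon; the step from compound 1 to compound 3 adds a group instead, so it bears only loosely on this change. A step within the scatter is therefore expected, a 1.4-fold higher number from compound 1 to compound 4 (0.15 log units; within the scatter). Compound 4 is estimated at 100 nM, between 30 nM and 400 nM.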

Compound 4, half-maximal inhibitory concentration: 200 nM
Estimate against measurement, compound 4: 2.0-fold (0.30 log units) below, within the range that was stated.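

In this assay, chloro in place of methyl on the aromatic carbon ortho to the (ethoxycarbonyl)amino group gives a 2.9-fold higher number from compound 1 to compound 4 (0.46 log units; beyond the scatter), so the two groups are not interchangeable here, although the step is modest. For the compounds shown here, this is the first swap at this carbon, and it shows that activity survives the loss of methyl. Compound 4 keeps a measured number and does not sit at the limit: the limit of > 10000 nM in this assay, at which 2 of the 4 values shown sit.

The compounds shown leave open whether methyl is the best group at this carbon. Fluoro, methoxy or an amine there would show how far the trend extends.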